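Swapping the Amine Tail of Compound 2 for a Plain Chain

A few compounds are considered here, and "the series" means these few. Any claim that something is new, unique, unknown or untested is made for them only; others in the source may bear on it.

Measured so far:
Compound 1, `CCN(CC)CCCC(C)Nc1ccnc(COc2ccc(F)cc2)c1`, gives 18000 nM in an assay on isolated protein for inhibition of C-C chemokine receptor type 4 (Homo sapiens); on this read-out higher numbers stand for weaker inhibition and lower numbers for stronger inhibition.
Compound 2, `CCN(CC)CCCNc1nccc(OCc2ccc(Cl)cc2Cl)n1`, gives 8000 nM in this assay.

Of these two numbers, compound 2 holds the lower one, and compound 1 sits higher by a gap beyond the usual scatter, so compound 2 is the stronger inhibitor of the pair. The two compounds differ in several places at once, however, so the gap cannot be tied to any single change.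

Compound 3, `CC(C)CCCC(C)Nc1nccc(OCc2ccc(Cl)cc2Cl)n1`, is compound 2 with one alteration: 1,5-dimethylhexyl in place of 3-(diethylamino)propyl on a nitrogen on an aromatic ring. Within the data shown here, no pair of measured compounds shows what such a swap does on this read-out, so the expectation rests on the structures alone and carries wide uncertainty. The expected step is a 3.1-fold higher number from compound 2 to compound 3 (0.49 log units; beyond the scatter), towards a higher number, that is, towards weaker inhibition, and clearly beyond the scatter. For compound 3 the estimated value in this assay is 25000 nM, with a likely range from 6000 nM to 100000 nM.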

Compound 3, half-maximal inhibitory concentration: > 10000 nM
Compound 3 ended at the assay's limit; the forecaster's own chance of this, stated with the estimate: 25%; the middle value does not contradict the limit.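

Among these compounds, this is the first comparison in which only the group on a nitrogen on an aromatic ring changes, with a tail that contains a nitrogen giving way to the all-carbon 1,5-dimethylhexyl, which has the same count of heavy atoms. In this assay compound 3 gives > 10000 nM, which is a limit of the assay and not a number. On these data alone, the change can therefore be stated only as a floor, an at least 1.2-fold higher number from compound 2 to compound 3 (0.09 log units; that floor lies within the scatter), so the all-carbon chain brings no stronger inhibition, while the size of any loss stays unknown, and that floor alone does not establish a real loss.

As far as these compounds go, whether the nitrogen in the tail of compound 2 matters therefore remains open, and so does the question of what other tails would do on this core, such as a chain carrying a primary amine, a piperidine ring or a carboxylic acid. Compound 1 differs from compound 2 in several places, so it cannot settle this question.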